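Fluoro in place of anilinomethyl: what compound 3 may show

The source may report more compounds than this note shows. Statements on the series, on what has been measured and on what is new or still open speak of the compounds shown alone.

Measured in an ADME assay on microsomes from liver (Homo sapiens) for metabolic stability, read by LC-MS, with a stated time of 1 h; a lower number here means that less of the compound is left, a higher number that more of the compound is left:
Compound 1 `O=[N+]([O-])c1cn2c(n1)OC[C@@H](OCc1ccc(-c3ccccc3OCCCO)cc1)C2`: 59%
Compound 2 `O=[N+]([O-])c1cn2c(n1)OC[C@@H](OCc1ccc(-c3ccc(CNc4ccccc4)cc3)cc1)C2`: 12%

Compound 2, at 12%, stands lowest of the two measured compounds, and the gap up to compound 1 lies beyond the scatter. Compound 3 `O=[N+]([O-])c1cn2c(n1)OC[C@@H](OCc1ccc(-c3ccc(F)cc3)cc1)C2` carries fluoro in place of anilinomethyl on an aromatic carbon, para to a large group: fluoro in place of anilinomethyl on an aromatic carbon. Among the measured compounds shown here, no measured pair shows this change directly. Still, compound 1, which lacks anilinomethyl, stands at 59%. A rise beyond the scatter is therefore expected, with an estimated step of a number 50 percentage points higher from compound 2 to compound 3 (beyond the scatter). For compound 3 the estimated value is 62%, with an expected range from 35% to 88%.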

Compound 3, percent of the compound remaining: 75%
Compound 3: middle estimate off by 13 percentage points, on the low side; the range from low to high includes it.
By their numbers in this assay, from the lowest: compound 2; then compound 1; then compound 3.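

At this aromatic carbon, para to a large group, the first directly comparable pair shows that the position strongly affects the result in this assay: fluoro in place of anilinomethyl gives a large change, a number 63 percentage points higher from compound 2 to compound 3 (beyond the scatter). The earlier compounds shown here differed in more than one place, so they could not tie a change to this carbon alone. Nothing measured here explains the change. The compounds shown leave open whether the step follows from the loss of anilinomethyl or from the presence of fluoro. Going by these compounds, how a methoxy group, an amine or a carboxylic acid at this carbon would read in this assay also remains open.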